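Cytotoxicity on hepatoma cells across three analogues, one pending

The source may hold more compounds than are shown below. What is called first, only, known or untested is meant among the compounds shown, and "the series" means these compounds.

Measured so far:
compound 1 `CC(c1ccc(N(CCCCN(C)C)C(=O)O)cc1)n1nc(-c2ccc(F)cc2)c2ccccc2c1=O`, 15200 nM
compound 2 `CN(C)CCCCN(C(=O)O)c1ccc(N2N=C(c3ccc(F)cc3)C3C=CC=CC3C2=O)cc1`, 21800 nM
compound 3 `CN(C)CCCCOC(=O)Nc1ccc(Cn2nc(-c3ccc(C#N)cc3)c3ccccc3c2=O)cc1`, 37000 nM

In an ADME assay on Huh-7 cells (Homo sapiens) for cytotoxicity, read by MTT assay, with a stated time of 48 h (a lower number here means that less compound is tolerated, a higher number that more compound is tolerated), compound 3 gives the highest of the three numbers. Against compound 2 the gap is within the scatter; against compound 1 it lies beyond it.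

Compound 4 `COc1ccccc1-c1nn(Cc2ccc(NC(=O)OCCCCN(C)C)cc2)c(=O)c2ccccc12` is not yet measured. It differs from compound 3 by 2-methoxyphenyl in place of 4-cyanophenyl on an aromatic carbon, on the aromatic carbon next to the ring nitrogen and ortho to a fused ring.

Within the data shown here, no step between measured compounds isolates this kind of swap, so no direction is supported by the data. The expectation is a step from compound 3 to compound 4 of a 1.2-fold lower number from compound 3 to compound 4 (0.09 log units; within the scatter), not beyond the scatter. Compound 4 is estimated at 30000 nM, within 12000 nM to 70000 nM in this assay.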

Compound 4, half-maximal cytotoxic concentration: 44800 nM
For compound 4 the middle estimate is 1.5-fold (0.17 log units) below the measured one; the measured number falls inside the stated range.
By their numbers in this assay, from the lowest: compounds 1, 2, 3 and 4 (each within the scatter of the next, the first and the last beyond it).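

In this assay, among these compounds, the swap to 2-methoxyphenyl in place of 4-cyanophenyl gives a 1.2-fold higher number from compound 3 to compound 4 (0.08 log units; within the scatter) on the aromatic carbon next to the ring nitrogen, the first step that can be read at this position. The two aryl groups, with the same count of heavy atoms and of hydrogen-bond acceptors, therefore stay within the scatter of each other in this series.

From the compounds shown here alone, whether a phenyl carrying an amine or a carboxylic acid at this position would stay within the scatter remains open. Nothing measured here gives a reason for this result.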